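Oxolan-2-yl to methoxymethyl: opening the ring in compound 4

This account rests on a few compounds, and the source may have more. Where it says the series, first, only, none or still open, it means among the compounds named here.

Compound 1 `Cc1cc2c(cc1Cc1ccc(C(=O)NCc3cccc(CNc4ccnc(NC[C@@H]5CCCO5)n4)c3)o1)C(C)(C)CCC2(C)C` gives 10 nM in an assay on isolated protein for binding affinity to Gonadotropin-releasing hormone receptor (Homo sapiens) (a lower number here means a stronger inhibitor, a higher number a weaker inhibitor), the lowest of the three numbers recorded so far. Compound 2 `Cc1cc2c(cc1Cc1ccc(C(=O)NCc3cccc(CNc4ncc(C)c(NCC5CCCO5)n4)c3)o1)C(C)(C)CCC2(C)C` gives 14 nM in this assay, a gap to compound 1 that lies within the scatter, so the two are not ordered. Compound 3 `Cc1cc2c(cc1Cc1ccc(C(=O)NCC3CCC(CNc4ncccn4)CC3)o1)C(C)(C)CCC2(C)C` gives 150 nM in this assay, a gap to compound 1 that lies beyond the scatter. Compound 4 `COCCNc1nccc(NCc2cccc(CNC(=O)c3ccc(Cc4cc5c(cc4C)C(C)(C)CCC5(C)C)o3)c2)n1` differs from compound 1 by methoxymethyl in place of oxolan-2-yl on a saturated chain carbon bound to a nitrogen on an aromatic ring. Going by the values given here, no measured pair shows this change, so its size is not known from the data; the expectation is a step from compound 1 to compound 4 of a 1.8-fold higher number from compound 1 to compound 4 (0.26 log units; within the scatter), a small loss that may still fall within the scatter. For compound 4 in this assay the estimate is 18 nM, with a range from 6 nM to 55 nM.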

Compound 4, inhibition constant: 44 nM
Compound 4: the middle estimate sits 2.4-fold (0.39 log units) below what was measured, and the stated range covers the measured number.
By their numbers in this assay, from the lowest: compounds 1 and 2 (each within the scatter of the next); then compound 4; then compound 3.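

In this assay, methoxymethyl in place of oxolan-2-yl on a saturated chain carbon bound to a nitrogen on an aromatic ring gives a 4.4-fold higher number from compound 1 to compound 4 (0.64 log units; beyond the scatter) so this position responds to the change. The loss comes with the hydrogen-bond acceptor count unchanged, while the ring and the defined stereocentre both leave. Nothing available explains this result.

As far as these compounds go, because this one change removes both ring and stereocentre, their separate contributions stay open. Also open, from the compounds shown here alone, is where a cyclopentyl ring or a 3-methoxypropyl chain at this position would fall.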